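Opening the pyrrolidine ring of compound 3 into a chain

The compounds below may be only part of what the source reports. "The series", "measured", "known", "first", "only" and "open" are said of these compounds alone.

Three compounds share one core and differ only in the side group on an aromatic carbon. Compound 1 `CN[C@@H]1CCN(c2cc3c(cc2F)c(=O)c(C(=O)O)cn3Cc2ccc(-c3ccccc3)cc2)C1` gives, in an assay on isolated protein for inhibition of DNA topoisomerase 1 (Homo sapiens), with a stated time of 15 min (on this read-out lower numbers stand for stronger inhibition and higher numbers for weaker inhibition), 34800 nM. Compound 2 `CNCCNc1cc2c(cc1F)c(=O)c(C(=O)O)cn2Cc1ccc(-c2ccccc2)cc1` reaches only a limit of this assay, > 200000 nM, so no number is known for it. Compound 3 `O=C(O)c1cn(Cc2ccc(-c3ccccc3)cc2)c2cc(NC[C@H]3CCNC3)c(F)cc2c1=O` gives 100000 nM, the highest of the two numbers shown; the step from compound 1 is a 2.9-fold higher number from compound 1 to compound 3 (0.46 log units; beyond the scatter), and the step to compound 2 is an at least 5.7-fold higher number from compound 1 to compound 2 (0.75 log units; beyond the scatter).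

Compound 4 `CNCCCNc1cc2c(cc1F)c(=O)c(C(=O)O)cn2Cc1ccc(-c2ccccc2)cc1` is the untested analogue. It differs from compound 3 in that (2-(methylamino)ethyl in place of pyrrolidin-3-yl on a saturated chain carbon bound to a nitrogen on an aromatic ring). The closest measured step is an at least 2.0-fold lower number from compound 2 to compound 3 (0.30 log units; that floor lies within the scatter), where the chain form sat at the limit of > 200000 nM in this assay, at which 1 of the 3 values shown sits, and the ring form gave a number. Opening the ring again is therefore expected to give a weaker inhibitor, with a step of about a 2.0-fold higher number from compound 3 to compound 4 (0.30 log units; within the scatter), and a fair chance that only a limit is reported. For compound 4 the estimate in this assay is 200000 nM, within a range of 80000 nM to 500000 nM.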

Compound 4, half-maximal inhibitory concentration: 63600 nM
Compound 4: middle estimate off by 3.1-fold (0.50 log units), on the high side; measured number below the stated range.
By their numbers in this assay, from the lowest: compounds 1, 4 and 3 (each within the scatter of the next, the first and the last beyond it). At a limit, above all of these: compound 2.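

In this assay compound 4, with its open 3-(methylamino)propyl chain, cannot be told apart from either ring compound (a 1.6-fold lower number from compound 3 to compound 4 (0.20 log units; within the scatter) and a 1.8-fold higher number from compound 1 to compound 4 (0.26 log units; within the scatter)), so at this position opening the ring shows no readable cost. Chain length does separate the two open forms (an at least 3.1-fold lower number from compound 2 to compound 4 (0.49 log units; beyond the scatter)), so the failure of compound 2 to give a number did not mean that every open chain would fail. Compound 2 with its (2-(methylamino)ethyl)amino group remains a limit of the assay and not a number: the limit of > 200000 nM in this assay, at which 1 of the 4 values shown sits.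

As far as these compounds go, whether a still longer chain, such as 4-(methylamino)butyl, would differ beyond the scatter stays open. So does the effect of a primary amine or a dimethylamino group at the chain end.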